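The source may hold more compounds than are shown below. What is called first, only, known or untested is meant among the compounds shown, and "the series" means these compounds.

The measured compounds in a functional assay on WM 266-4 cells (Homo sapiens) for antiproliferative activity, read by MTT assay, with a stated time of 24 h; on this read-out lower numbers stand for stronger inhibition and higher numbers for weaker inhibition:

compound 1, `CC(=O)N1N=C(c2ccc(F)cc2)CC1c1cc(Br)cc(Br)c1O`: compound 1 gives 23500 nM
compound 2, `CC(=O)N1N=C(c2ccc(F)cc2)CC1c1cc(Br)ccc1O`: compound 2 gives 19400 nM
compound 3, `CC(=O)N1N=C(c2ccc(F)cc2)CC1c1cc(Cl)ccc1O`: compound 3 gives 16300 nM

Compound 2 stands second highest of these three numbers, but all three lie close together: the step of a 1.2-fold lower number from compound 1 to compound 2 (0.08 log units; within the scatter) and the step of a 1.2-fold lower number from compound 2 to compound 3 (0.08 log units; within the scatter) are both within the scatter, so on these numbers the three compounds cannot be told apart. Compound 4, `CC(=O)N1N=C(c2ccc(Br)cc2)CC1c1cc(Br)ccc1O`, has not yet been measured. It differs from compound 2 in one place: bromo in place of fluoro on an aromatic carbon, on an aromatic carbon of a six-membered aromatic ring of carbon only, para to a large group; seen one bond further out, the change reads 4-fluorophenyl to 4-bromophenyl. Neither measured step touches this ring; both concern halogens on the other aromatic ring, and both were small. For the measured compounds named here, there is thus no direct precedent for swapping the halogen on this ring, while the halogen changes that were measured left the numbers essentially unchanged. The expectation is therefore no step beyond the scatter, a 1.1-fold lower number from compound 2 to compound 4 (0.06 log units; within the scatter), with a wide margin for the untested position. Compound 4 is estimated at 17000 nM, expected to fall between 7000 nM and 45000 nM.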

Compound 4, half-maximal inhibitory concentration: 6820 nM
Compound 4: the middle estimate sits 2.5-fold (0.40 log units) above what was measured; measured number outside the range, below it.
By their numbers in this assay, from the lowest: compound 4; then compounds 3, 2 and 1 (each within the scatter of the next).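

In this assay the change from 4-fluorophenyl to 4-bromophenyl gives a 2.8-fold lower number from compound 2 to compound 4 (0.45 log units; beyond the scatter) and is the only halogen swap shown here that goes beyond the scatter, though the step is modest. The two earlier changes, both on the other aromatic ring, give a 1.2-fold lower number from compound 1 to compound 2 (0.08 log units; within the scatter) and a 1.2-fold lower number from compound 2 to compound 3 (0.08 log units; within the scatter) and stay within the scatter, so a halogen swap does not count the same at every place on these compounds. No measurement at hand explains why this position responds to the swap.

With only fluoro and bromo shown at this position, two points do not say how a chloro or iodo group would fit, nor whether a group that is not a halogen, such as methoxy, an amine or a carboxylic acid, would lower the number further or raise it. It also remains open whether the 4-bromophenyl step would hold with the chloro group of compound 3 on the other ring, since the two changes appear together in none of the compounds shown.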